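Cathepsin S inhibitors: swapping a five-membered for six-membered ring

A few compounds are considered here, and "the series" means these few. Any claim that something is new, unique, unknown or untested is made for them only; others in the source may bear on it.

Compound 1, `O=C(N[C@@H](CC1CCCCC1)C(=O)NCCNc1ccc(OC(F)(F)F)cc1)c1ccc(-c2cccc(C(F)(F)F)c2)o1`, in an assay on isolated protein for inhibition of cathepsin S (Homo sapiens) (on this read-out higher numbers stand for weaker inhibition and lower numbers for stronger inhibition), gives 11 nM.
Compound 2, `O=C(N[C@@H](CC1CCCCC1)C(=O)NCCNc1ccc(OC(F)(F)F)cc1)c1cc2ccccc2o1`, in this assay gives 17 nM.
Compound 3, `C[C@@H](CNc1ccc(OC(F)(F)F)cc1)NC(=O)[C@H](CC1CCCCC1)NC(=O)O[C@H]1CCOC1`, in this assay gives 49 nM.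

Among these three, compound 3 carries the highest number in this assay, and its gap to each of the other two lies beyond the usual scatter, so it is the weakest inhibitor of the set. Compound 4, `C[C@@H](CNc1ccc(OC(F)(F)F)cc1)NC(=O)[C@H](CC1CCCCC1)NC(=O)OC1CCOCC1`, differs from compound 3 by one change: oxan-4-yl in place of oxolan-3-yl on an oxygen next to a carbonyl group. For the measured compounds named here, no measured pair in this set shows the effect of such a ring-size change, so the expectation rests on the change alone. An expected step of a 1.0-fold higher number from compound 3 to compound 4 (0.01 log units; within the scatter) means little movement, probably none beyond the scatter. Compound 4 is therefore estimated at 50 nM, within a range of 20 nM to 130 nM.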

Compound 4, inhibition constant: 12 nM
Compound 4: middle estimate off by 4.2-fold (0.62 log units), on the high side; the whole stated range lies above it.
By their numbers in this assay, from the lowest: compounds 1, 4 and 2 (each within the scatter of the next); then compound 3.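

On an oxygen next to a carbonyl group, ring size matters: in this assay, oxan-4-yl in place of oxolan-3-yl gives a 4.1-fold lower number from compound 3 to compound 4 (0.61 log units; beyond the scatter) and so stronger inhibition. The change leaves the counted hydrogen-bond donors and acceptors as they were, but it does remove the defined stereocentre of the ring. No measurement here bears on the reason for this step.

Open, going by these compounds, is whether a piperidin-4-yl ring, which carries an amine, would match the oxan-4-yl ring on this oxygen. Also open, on these data alone, is whether a seven-membered ring would move the number further.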